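The source may report more compounds than this note shows. Statements on the series, on what has been measured and on what is new or still open speak of the compounds shown alone.

Among the compounds with values here, in a functional assay on HT-1080 cells (Homo sapiens) for antiproliferative activity, read by MTT assay, with a stated time of 72 h (a lower number here means a stronger inhibitor, a higher number a weaker inhibitor), compound 2 (`COc1ccc(-c2sccc2-c2cc(OC)c(OC)c(OC)c2)cc1`) gives 4590 nM as the lower of the two numbers so far. Compound 1 (`COc1ccc(-c2sc(C(=O)O)cc2-c2cc(OC)c(OC)c(OC)c2)cc1[N+](=O)[O-]`) gives 37200 nM in the same read-out. The gap between these two numbers lies beyond the scatter. Compound 3 (`COc1ccc(-c2sccc2-c2cc(OC)c(OC)c(OC)c2)cc1[N+](=O)[O-]`) has nitro in place of hydrogen on an aromatic carbon of compound 2, ortho to a methoxy group (nitro in place of hydrogen on an aromatic carbon). Within the data shown here, no measured step isolates this change. Compound 1 also carries nitro and stands at 37200 nM (the higher number), so a modest rise in this assay is expected, possibly within the scatter. The expected move is a 1.4-fold higher number from compound 2 to compound 3 (0.15 log units; within the scatter) (an estimate only). The estimate for compound 3 is 6500 nM (expected range 1800 nM to 25000 nM).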

Compound 3, half-maximal inhibitory concentration: 2100 nM
For compound 3 the middle estimate is 3.1-fold (0.49 log units) above the measured one; the range from low to high includes it.
By their numbers in this assay, from the lowest: compound 3; then compound 2; then compound 1.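

In this assay nitro in place of hydrogen, ortho to a methoxy group, gives a 2.2-fold lower number from compound 2 to compound 3 (0.34 log units; beyond the scatter) and so is tolerated at this position. Hydrogen in place of carboxy on an aromatic carbon gives an 18-fold lower number from compound 1 to compound 3 (1.25 log units; beyond the scatter) as a large step, which ties the high number of compound 1 to its carboxy group and not to its nitro group. Nothing at hand explains either step. As far as these compounds go, how an amine or a fluorine would compare with nitro at this position remains open, as does whether a methyl ester in place of carboxy would keep the high number.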